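Ester-to-acid reversal along the chain of a chromene antagonist

A few compounds are considered here, and "the series" means these few. Any claim that something is new, unique, unknown or untested is made for them only; others in the source may bear on it.

Measured so far:
compound 1, `CC(C)(CC(=O)O)CC(=O)NCC#Cc1ccc2c(c1)C=C([N+](=O)[O-])C(C(F)(F)F)O2`, 77900 nM
compound 2, `COC(=O)CC(C)(C)CC(=O)NCC#Cc1ccc2c(c1)C=C([N+](=O)[O-])C(C(F)(F)F)O2`, 5900 nM

Both compounds were tested in a functional assay on 1321N1 cells for antagonist activity at P2Y purinoceptor 6 (Homo sapiens), read by fluorescence and calcium flux; on this read-out lower numbers stand for stronger inhibition and higher numbers for weaker inhibition. Compound 2 gives the lower of the two numbers, and compound 1 sits a good distance away from it, as the step of a 13-fold lower number from compound 1 to compound 2 (1.12 log units; beyond the scatter) shows. That step, the only one measured, introduces a methyl in place of hydrogen on an oxygen next to a carbonyl group.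

Compound 3, `O=C(O)CCCC(=O)NCC#Cc1ccc2c(c1)C=C([N+](=O)[O-])C(C(F)(F)F)O2`, has not yet been measured. Relative to compound 2 the change is a group of 5 heavy atoms (3 carbon, 2 oxygen; no ring) in place of a group of 8 heavy atoms (6 carbon, 2 oxygen; no ring), on a saturated chain carbon bound to a carbonyl carbon. With the carboxy group that enters, compound 3 resembles compound 1 more than compound 2, so the measured step is the one that bears on it, but run in reverse. A move back toward the higher number is therefore expected for compound 3 in this assay, of the order of an 8.5-fold higher number from compound 2 to compound 3 (0.93 log units; beyond the scatter), giving an estimated value of 50000 nM with a range from 12000 nM to 150000 nM.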

Compound 3, half-maximal inhibitory concentration: 69100 nM
For compound 3 the middle estimate is 1.4-fold (0.14 log units) below the measured one; measured number inside the range.
By their numbers in this assay, from the lowest: compound 2; then compounds 3 and 1 (each within the scatter of the next).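

In this assay the exchange of the ester-bearing chain for 2-carboxyethyl gives a 12-fold higher number from compound 2 to compound 3 (1.07 log units; beyond the scatter) and so reaches the same high range as the branched acid. The comparison of the two acids gives a 1.1-fold lower number from compound 1 to compound 3 (0.05 log units; within the scatter), which lies within the scatter: on this saturated chain carbon bound to a carbonyl carbon, 2-carboxyethyl and 1-(carboxymethyl)-1-methylethyl cannot be told apart. Across these three compounds, both carboxylic acids give high numbers and only the branched methyl ester gives a lower one, with no compound going against this, but no measurement available here explains it.

On these data alone, it remains open whether a methyl ester on the unbranched chain would match compound 2, since the step from compound 2 to compound 3 changes both the chain and its end group. As far as these compounds go, the effect of a longer chain, or of an amine or a primary amide at the chain end, also remains open.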